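The compounds below may be only part of what the source reports. "The series", "measured", "known", "first", "only" and "open" are said of these compounds alone.

Of the compounds shown here, three share a succinimide-bearing amide chain and have been tested in a functional assay on the whole organism (strain Swiss) with Mus musculus as the target, in the maximal electroshock model, with a stated time of 2 h, at a dose of 300 mg/kg by the intraperitoneal route; on this read-out lower numbers stand for a weaker effect and higher numbers for a stronger effect at the one dose given. Compound 1 `COc1cccc(N2CCN(C(=O)C(C)N3C(=O)CCC3=O)CC2)c1` gives 0%, compound 3 `CC(C(=O)N1CCOCC1)N1C(=O)CCC1=O` gives 0%, and compound 2 `COCC(C(=O)N1CCN(c2cccc(C(F)(F)F)c2)CC1)N1C(=O)CCC1=O` gives 100%, the highest of the three numbers, with both other compounds beyond the scatter below it. Compound 4 `CCC(C(=O)N1CCN(c2cccc(C(F)(F)F)c2)CC1)N1C(=O)CCC1=O` differs from compound 2 in one place: methyl in place of methoxy on a saturated chain carbon, two bonds along the chain from an amide-type nitrogen in a ring and a carbonyl carbon. Compound 1 and compound 3 both carry a methyl on that saturated chain carbon, yet each gives a value far below compound 2, so the expected step in this assay a number 50 percentage points lower from compound 2 to compound 4 (beyond the scatter) is downward. Because compound 1 gives 0% while its aryl group also differs, the drop is uncertain, and compound 4 is expected to give about 50%, between 0% and 100%.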

Compound 4, a percentage reported as activity, at one dose (the size of the read-out at that dose, not a potency): 50%
The estimate for compound 4 equals the measured number at the digits printed, within the range that was stated.
By their numbers in this assay, from the lowest: compounds 1 and 3 (each within the scatter of the next); then compound 4; then compound 2.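

Methyl in place of methoxy on this saturated chain carbon gives a number 50 percentage points lower from compound 2 to compound 4 (beyond the scatter) in this assay, the first comparison here of compounds differing in one place, so a change at this position alone can shift the read-out. The effect is reduced but not lost: compound 4 gives 50% at this one dose, so methoxy is not needed for some activity. Nothing measured here explains the drop.

From the compounds shown here alone, what an amine, a hydroxyl or a longer chain on this carbon would give remains open. So does whether the same change would shift the read-out on the core of compound 1.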